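A few compounds are considered here, and "the series" means these few. Any claim that something is new, unique, unknown or untested is made for them only; others in the source may bear on it.

In a functional assay on CCRF-CEM cells (Homo sapiens) for antiproliferative activity, with a stated time of 72 h (on this read-out lower numbers stand for stronger inhibition and higher numbers for weaker inhibition), compound 1 `OC[C@H]1O[C@@H](n2cnc3c(NCc4cccc(F)c4)ncnc32)[C@H](O)[C@@H]1O` gives 4000 nM and compound 2 `OC[C@H]1O[C@@H](n2cnc3c(NCc4ccc(Cl)cc4)ncnc32)[C@H](O)[C@@H]1O` gives 10200 nM, so compound 2 holds the higher of the two numbers. Compound 3 `OC[C@H]1O[C@@H](n2cnc3c(NCc4ccccc4Br)ncnc32)[C@H](O)[C@@H]1O` carries 2-bromophenyl in place of 4-chlorophenyl on a saturated chain carbon bound to a nitrogen on an aromatic ring. Among the measured compounds shown here, only one measured step bears on this change: a 2.6-fold higher number from compound 1 to compound 2 (0.41 log units; beyond the scatter), a modest move in which 4-chlorophenyl replaced 3-fluorophenyl at the same place. For the measured compounds named here, no measured compound carries 2-bromophenyl, so this evidence is indirect. With compound 1 at 4000 nM as the only lower reference, a small move toward a lower number is expected in this assay, probably not clearly beyond the scatter. The expected change is a 1.6-fold lower number from compound 2 to compound 3 (0.20 log units; within the scatter). For compound 3 the estimated value is 6500 nM, with an expected range of 2000 nM to 20000 nM.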

Compound 3, half-maximal inhibitory concentration: 12300 nM
Compound 3: the middle estimate sits 1.9-fold (0.28 log units) below what was measured; the range from low to high includes it.
By their numbers in this assay, from the lowest: compound 1; then compounds 2 and 3 (each within the scatter of the next).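

In this assay, putting 2-bromophenyl in place of 4-chlorophenyl on a saturated chain carbon bound to a nitrogen on an aromatic ring gives a 1.2-fold higher number from compound 2 to compound 3 (0.08 log units; within the scatter) and so leaves compound 2 and compound 3 indistinguishable, although both the halogen and the numbered ring position differ. Against the 3-fluorophenyl group of compound 1, the same 2-bromophenyl group gives a 3.1-fold higher number from compound 1 to compound 3 (0.49 log units; beyond the scatter) and so makes 3-fluorophenyl the one group of the three set apart from the other two, with the lowest number. Nothing on hand gives a reason for this pattern.

Halogen and ring position change together in every step, so the compounds shown do not separate the two. They also leave open how this assay would read an unsubstituted phenyl, a methoxy group on the ring or a longer chain in place of the benzyl link.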